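Thioamide terminus: configuration change at the chain carbon

A few compounds are considered here, and "the series" means these few. Any claim that something is new, unique, unknown or untested is made for them only; others in the source may bear on it.

The series shares one core, carried through three compounds with a carbamate-protected amine at a saturated chain carbon and a varied terminal group. Compound 1 `CCOC(=O)c1csc(-c2csc(-c3csc([C@H](C)NC(=O)OC(C)(C)C)n3)n2)n1` bears an ester at the terminus; in a functional assay on HCT-116 cells (Homo sapiens) for inhibition, read by CCK-8 assay, tested at 50 uM (on this read-out lower numbers stand for less inhibition and higher numbers for more inhibition at the one concentration tested (going by the name of the read-out)), compound 1 is reported as "active" (no number reported) with no number attached. Compound 2 `C[C@H](NC(=O)OC(C)(C)C)c1nc(-c2nc(-c3nc(C(N)=O)cs3)cs2)cs1` carries an amide there and in this assay compound 2 gives 70%. Compound 3 `C[C@@H](NC(=O)OC(C)(C)C)c1nc(-c2nc(-c3nc(C(N)=S)cs3)cs2)cs1` carries a thioamide, and in this assay compound 3 gives 70%, level with compound 2 at the digits printed and within the scatter of it; compound 1 offers no number to compare against. Within the data shown here, no pair among the measured compounds differs in a single place, so no step in this assay is known.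

Compound 4 `C[C@H](NC(=O)OC(C)(C)C)c1nc(-c2nc(-c3nc(C(N)=S)cs3)cs2)cs1` is the next entry. It differs from compound 3 as follows: the two compounds have the same atoms and bonds and differ only in configuration as drawn: 1 of 1 stereo elements differ; a stereocentre at a saturated chain carbon is drawn R in compound 3 and S in compound 4. With nothing leaving or entering, the only basis for an expectation is that both measured configurations so far sit at the same level. The step from compound 3 to compound 4 is therefore expected to stay within the scatter, as a number 2 percentage points lower from compound 3 to compound 4 (within the scatter). Compound 4 is estimated at 68% in this assay, with a range from 45% to 88%.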

Compound 4, a percentage reported as inhibition, at one concentration (the size of the read-out at that concentration, not a potency): 70%
For compound 4 the middle estimate is 2 percentage points below the measured one; the measured number falls inside the stated range.
By their numbers in this assay, from the lowest: compounds 2, 3 and 4 (each within the scatter of the next).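

Inverting the stereocentre at the saturated chain carbon gives no change at the digits printed from compound 3 to compound 4 (within the scatter) in this assay and is the first single-place comparison in the series, so this centre now has a measured step rather than a comparison of compounds that also differ at the terminus. Any reading of that step concerns configuration alone, because nothing else separates the pair: the fact that compounds 3 and 4 differ only in the configuration as drawn. With the configuration matched, replacing the terminal amide with the thioamide gives no change at the digits printed from compound 2 to compound 4 (within the scatter) and thus isolates the exchange of oxygen for sulfur at this terminus, which the earlier comparison of compound 2 with compound 3 could not do.

Both steps rest on a single concentration, so they give no potency and leave open whether the stereoisomers or the amide and thioamide would separate at lower concentrations. As far as these compounds go, whether a carboxylic acid at the terminus or a free amine in place of the carbamate would hold this level also remains open, and compound 1, with its ester, gives only "active" (no number reported) and cannot be placed against the others.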